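The compounds below may be only part of what the source reports. "The series", "measured", "known", "first", "only" and "open" are said of these compounds alone.

Measured compounds:
compound 1 `CC(=O)Oc1ccc(/C=C/C(=O)OCCSc2nc(-c3ccc(S(C)(=O)=O)cc3)n(-c3ccccc3)n2)cc1OC(C)=O` — 1210 nM
compound 2 `CC(=O)Oc1ccc(/C=C/C(=O)NCCCSc2nc(-c3ccc(S(N)(=O)=O)cc3)n(-c3ccccc3)n2)cc1OC(C)=O` — 970 nM
compound 3 `COc1cc(/C=C/C(=O)OCCSc2nc(-c3ccc(S(C)(=O)=O)cc3)n(-c3ccc(Br)cc3)n2)ccc1OC(C)=O` — 940 nM

All three were tested in an assay on cells (strain Sprague-Dawley) for inhibition of Polyunsaturated fatty acid 5-lipoxygenase (Rattus norvegicus), with a stated time of 30 min; on this read-out higher numbers stand for weaker inhibition and lower numbers for stronger inhibition. Compound 3 shows the smallest of the three numbers, but its gaps to compound 2 and to compound 1 both lie within the usual scatter, so the three cannot be told apart on this read-out.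

Compound 4 `COc1cc(/C=C/C(=O)OCCSc2nc(-c3ccc(S(C)(=O)=O)cc3)n(-c3ccccc3)n2)ccc1OC(C)=O` is not yet measured. It differs from compound 3 by hydrogen in place of bromo on an aromatic carbon, para to a large group. Among the compounds with values here, no measured pair shows this change, so there is no step to lean on. A small step is expected, at most a mild weakening, and probably none beyond the scatter. The expected step from compound 3 to compound 4 is a 1.3-fold higher number from compound 3 to compound 4 (0.11 log units; within the scatter). Compound 4 is therefore estimated at 1200 nM, within a range from 500 nM to 3000 nM.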

Compound 4, half-maximal inhibitory concentration: 960 nM
Beside the measured number, compound 4's estimate is 1.3-fold (0.10 log units) above it; measured number inside the range.
By their numbers in this assay, from the lowest: compounds 3, 4, 2 and 1 (each within the scatter of the next).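

Swapping the bromo for hydrogen on this aromatic carbon, para to a large group (a 1.0-fold higher number from compound 3 to compound 4 (0.01 log units; within the scatter)), leaves compound 3 and compound 4 indistinguishable, so the bromo is not needed for the measured inhibition in this pair. Within the data shown here, compound 4 also gives the first one-place comparison at the oxygen on an aromatic ring: methyl in place of acetyl (a 1.3-fold lower number from compound 1 to compound 4 (0.10 log units; within the scatter)) likewise cannot be told apart.

On these data alone, whether a chlorine, a nitrile or an amine on that carbon, or a free hydroxyl on that oxygen, would fit the same picture stays open. No measurement shown explains why these changes leave the values so close.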